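A few compounds are considered here, and "the series" means these few. Any claim that something is new, unique, unknown or untested is made for them only; others in the source may bear on it.

Measured compounds:
compound 1 `CCCCCCCCCCc1ccc(-c2noc(C3CCNC3)n2)cc1` — 26%
compound 2 `CCCCCCCCCCc1ccc(-c2noc([C@@H]3CC[C@H](N)C3)n2)cc1` — 38%

In an assay on HeLa cells for inhibition of sphingosine-1-phosphate transporter SPNS2 (Mus musculus), read by LC-MS, tested at 2 uM (a lower number here means less inhibition, a higher number more inhibition at the concentration tested (going by the name of the read-out)), compound 1 gives the lower of the two numbers; compound 2 stands higher, a number 12 percentage points higher from compound 1 to compound 2 (beyond the scatter). Compound 3 `CCCCCCCCCCc1ccc(-c2noc(CCCN3CCCCC3)n2)cc1` is not yet measured. It differs from compound 1 in one place: 3-(piperidin-1-yl)propyl in place of pyrrolidin-3-yl on an aromatic carbon. Within the data shown here, the only measured step, a number 12 percentage points higher from compound 1 to compound 2 (beyond the scatter), swaps the same pyrrolidin-3-yl for 3-aminocyclopentyl, a different replacement, so it bears on this step only loosely. Among the measured compounds shown here, no step tests the 3-(piperidin-1-yl)propyl group itself. Compound 3 is therefore expected to stay near compound 1, with a step of about a number 4 percentage points higher from compound 1 to compound 3 (within the scatter), not clearly beyond the scatter. The estimate for compound 3 is 30%, in the range 10% to 55%.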

Compound 3, a percentage reported as inhibition, at one concentration (the size of the read-out at that concentration, not a potency): 0%
Estimate against measurement, compound 3: 30 percentage points above; measured number outside the range, below it.
By their numbers in this assay, from the lowest: compound 3; then compound 1; then compound 2.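

In this assay, this position proves able to lose the read-out entirely: a number 26 percentage points lower from compound 1 to compound 3 (beyond the scatter), and a number 38 percentage points lower from compound 2 to compound 3 (beyond the scatter). The change from pyrrolidin-3-yl to 3-(piperidin-1-yl)propyl raises the heavy atoms from 5 to 9 and the hydrogen-bond donors from 1 to 0 at once, so a nitrogen-bearing group at this carbon does not by itself keep the inhibition. Nothing available explains the loss. Still open, going by these compounds, is whether a piperidin-4-yl group attached directly, or a 3-aminopropyl chain, would separate the effect of the chain from that of the ring.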